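The source may hold more compounds than are shown below. What is called first, only, known or untested is meant among the compounds shown, and "the series" means these compounds.

Measured so far:
compound 1, `COc1ccc(-c2nc(SCC(=O)c3sc(-c4ccccc4)nc3C)nc(N)c2C#N)cc1`: 17.2%
compound 2, `Cc1nc(-c2ccccc2)sc1C(=O)CSc1nc(N)c(C#N)c(-c2ccc(Cl)cc2)n1`: 17.1%
compound 3, `Cc1nc(-c2ccccc2)sc1C(=O)CSc1nc(N)c(C#N)c(-c2ccccc2)n1`: 6.48%

In a functional assay on U-87MG ATCC cells for antiproliferative activity against U-87 MG (Homo sapiens), read by MTT assay, with a stated time of 48 h, tested at 100 uM (a higher number here means a weaker effect of the compound at the concentration tested, a lower number a stronger effect), compound 1 stands highest of the three, with compound 2 nearest and within the scatter, and compound 3 furthest, a modest step lower.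

Compound 4, `COc1ccc(-c2nc(SCC(=O)c3sc(-c4ccc(Cl)cc4)nc3C)nc(N)c2C#N)cc1`, has not been measured. Against compound 1 its difference is chloro in place of hydrogen on an aromatic carbon, placed on the phenyl ring that sits on the thiazole part of the shared core, not on the ring where the measured compounds differ. Among the measured compounds shown here, two measured steps bear on it indirectly: a number 0.1 percentage points lower from compound 1 to compound 2 (within the scatter) showed that a chloro and a methoxy on the other ring give the same number, while a number 10.6 percentage points lower from compound 2 to compound 3 (beyond the scatter) showed that removing a chloro there lowers the number modestly; read in reverse, adding a chloro raised it. The rings are different, so the transfer is uncertain, but a small rise beyond the scatter, or none, is expected, giving a number 5.8 percentage points higher from compound 1 to compound 4 (within the scatter). Compound 4 is therefore estimated at 23%, within 10% to 38%.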

Compound 4, a percentage reported as activity, at one concentration (the size of the read-out at that concentration, not a potency): 0.79%
Compound 4: the middle estimate sits 22.2 percentage points above what was measured; the measured number lies below the stated range.
By their numbers in this assay, from the lowest: compounds 4 and 3 (each within the scatter of the next); then compounds 2 and 1 (each within the scatter of the next).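

In this assay, among the compounds shown here, the change from phenyl to 4-chlorophenyl, on the aromatic ring that stayed unchanged in the earlier compounds, gives a number 16.4 percentage points lower from compound 1 to compound 4 (beyond the scatter). Those compounds showed a chloro only on the other aromatic ring, where taking it away lowered the number, whereas here adding one lowers it. The direction of the exchange between chloro and hydrogen therefore differs with the ring that carries it, and the gap between the two steps is larger than a repeat measurement would explain: the same change on two cores in this assay, a number 10.6 percentage points lower (beyond the scatter) from compound 2 to compound 3 and a number 16.4 percentage points higher (beyond the scatter) from compound 4 to compound 1, 27 percentage points apart, beyond the scatter of two such steps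

As far as these compounds go, what a fluoro, a methoxy or an amine would do at this place stays open. So does whether the 4-chlorophenyl group gives the same step when the other aromatic ring carries hydrogen or chloro instead of methoxy.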